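This account rests on a few compounds, and the source may have more. Where it says the series, first, only, none or still open, it means among the compounds named here.

Of the compounds shown here, two with a shared core have been measured in an assay on isolated protein for displacement of a labelled ligand from melanin-concentrating hormone receptor 1 (Homo sapiens); a higher number here means a weaker inhibitor, a lower number a stronger inhibitor. Compound 1, `CC1CCCN1c1ccc2cc(NC(=O)CCc3ccc(C(F)(F)F)cc3)ccc2n1`, gives 5 nM in this assay. Within the data shown here, compound 2, `CN(c1ccc2cc(NC(=O)CCc3ccc(C(F)(F)F)cc3)ccc2n1)C1CCCC1`, gives 2 nM, and the single change between the two, a 2.5-fold lower number from compound 1 to compound 2 (0.40 log units; beyond the scatter), is a modest gain. Among the measured compounds shown here, on the numbers so far, compound 2 stands lowest of the two, with compound 1 the only neighbour.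

Compound 3, `Nc1ccc2cc(NC(=O)CCc3ccc(C(F)(F)F)cc3)ccc2n1`, carries a different change at the same position: amino in place of cyclopentyl(methyl)amino on an aromatic carbon. For the measured compounds named here, the one step measured so far compares two amines that each carry a five-membered ring; neither measured compound has a bare amino at this position, so no step speaks directly to this change. The measured step was modest, and the change here is larger in what is removed. The expectation is therefore a weakening, a higher number, of moderate size rather than none beyond the scatter.

Compound 3 is expected to give 25 nM, most likely between 6 nM and 120 nM. That expected shift amounts to a 13-fold higher number from compound 2 to compound 3 (1.10 log units; beyond the scatter).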

Compound 3, half-maximal inhibitory concentration: 240 nM
For compound 3 the middle estimate is 9.6-fold (0.98 log units) below the measured one; the whole stated range lies below it.
By their numbers in this assay, from the lowest: compound 2; then compound 1; then compound 3.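

In this assay, replacing cyclopentyl(methyl)amino with amino gives a 120-fold higher number from compound 2 to compound 3 (2.08 log units; beyond the scatter) and replacing 2-methylpyrrolidin-1-yl with amino gives a 48-fold higher number from compound 1 to compound 3 (1.68 log units; beyond the scatter), so both routes to the bare amino lead to a large rise in the number. Among these compounds, the earlier pair, with its step of a 2.5-fold lower number from compound 1 to compound 2 (0.40 log units; beyond the scatter), showed only that two ring-bearing amines on this aromatic carbon next to the ring nitrogen give similar low numbers, whereas the new steps show that this position is far from indifferent to what it carries. The change to amino removes the carbon ring and adds a hydrogen-bond donor in a single move, and no measurement available here says what lies behind the rise.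

The compounds shown leave open how much of the lost ground depends on the ring and how much on the remaining hydrogens of the amino nitrogen. A dimethylamino group, which has no ring and no hydrogen on its nitrogen, and a cyclopentylamino group, which keeps the ring and one such hydrogen, would pull those two changes apart.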